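The source may report more compounds than this note shows. Statements on the series, on what has been measured and on what is new or still open speak of the compounds shown alone.

Working notes on the solubility series.

Of the compounds shown here, three have been measured. Compound 1 `CCNC(=O)c1cc(N)c(Nc2ccc(C#N)cc2)cc1Oc1c(C)cc(/C=C/C#N)cc1C` gives 1.08 ug/mL in a physicochemical assay for solubility, read by HPLC, in phosphate buffer, with a stated time of 4 h, at pH 7.4; a higher number here means a more soluble compound, a lower number a less soluble compound. Compound 2 `Cc1cc(/C=C/C#N)cc(C)c1Oc1cc(Nc2ccc(C#N)cc2)c(N)cc1C(N)=O` gives 0.63 ug/mL in this assay, and compound 3 `Cc1cc(/C=C/C#N)cc(C)c1Oc1cc(Nc2ccc(C#N)cc2)c(N)cc1C(=O)NCCC(F)F` gives 6.59 ug/mL. Compound 3 stands highest of the three: the step of a 6.1-fold higher number from compound 1 to compound 3 (0.79 log units; beyond the scatter) and the step of a 10-fold higher number from compound 2 to compound 3 (1.02 log units; beyond the scatter) both lie beyond the scatter, whereas the step of a 1.7-fold lower number from compound 1 to compound 2 (0.23 log units; within the scatter) does not.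

Compound 4 `Cc1cc(/C=C/C#N)cc(C)c1Oc1cc(Nc2ccc(C#N)cc2)c(N)cc1C(=O)N1CC1` has not been measured. It differs from compound 3 by aziridin-1-yl in place of (3,3-difluoropropyl)amino on a carbonyl carbon. Going by the values given here, two measured steps bear on this change: the step of a 10-fold higher number from compound 2 to compound 3 (1.02 log units; beyond the scatter), in which the 3,3-difluoropropyl group enters on the amide-type nitrogen, and the step of a 6.1-fold higher number from compound 1 to compound 3 (0.79 log units; beyond the scatter), in which difluoromethyl enters on the chain. Going from compound 3 to compound 4 removes that same 3,3-difluoropropyl group and the amide hydrogen together, and in their place brings the aziridin-1-yl ring, for which no measured step exists. On the basis of the step from compound 2 to compound 3 being undone, a return toward the numbers of compound 1 and compound 2 is expected. For compound 4 this means an expected 5.5-fold lower number from compound 3 to compound 4 (0.74 log units; beyond the scatter). Compound 4 is therefore estimated at 1.2 ug/mL, with a range from 0.4 ug/mL to 4 ug/mL.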

Compound 4, solubility: 1.2 ug/mL
Compound 4: middle estimate and measured number agree at the digits printed, and the stated range covers the measured number.
By their numbers in this assay, from the lowest: compounds 2, 1 and 4 (each within the scatter of the next); then compound 3.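

In this assay, going by these compounds alone, the (3,3-difluoropropyl)amino group is the only one of the four groups on this carbonyl carbon that stands apart: replacing it gives a 5.5-fold lower number from compound 3 to compound 4 (0.74 log units; beyond the scatter). The aziridin-1-yl ring, with no amide hydrogen on its nitrogen, adds a new kind of group at this position, yet it is not separated from the smaller open groups, with a 1.9-fold higher number from compound 2 to compound 4 (0.28 log units; within the scatter) against amino and a 1.1-fold higher number from compound 1 to compound 4 (0.05 log units; within the scatter) against ethylamino. Across amino, ethylamino and aziridin-1-yl, then, neither the ring nor the loss of the amide hydrogen gives a number beyond the scatter, so the one high number in the series remains that of compound 3.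

No measurement on hand offers an explanation for these steps. Still open, from the compounds shown here alone, is whether a plain propyl chain on the amide nitrogen would keep the number of compound 3 without the fluorine atoms, and whether a larger ring on the carbonyl carbon, such as azetidin-1-yl or morpholin-4-yl, would stay with compound 4 or move away from it.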